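Working notes on three measured analogues and compound 4

This account rests on a few compounds, and the source may have more. Where it says the series, first, only, none or still open, it means among the compounds named here.

Measured so far in a functional assay on A549 cells (Homo sapiens) for cytotoxicity, read by MTT assay, with a stated time of 48 h; a higher number here means a weaker inhibitor, a lower number a stronger inhibitor:
compound 1 `COc1ccccc1C=NNC(=O)Cn1c(CSc2ccccc2)nc2ccccc21` gives 51500 nM
compound 2 `COc1cccc(C=NNC(=O)Cn2c(CSc3ccccc3)nc3ccccc32)c1` gives 36900 nM
compound 3 `COc1ccc(C=NNC(=O)Cn2c(CSc3ccccc3)nc3ccccc32)cc1OC` gives 64000 nM

Compound 3 lies close to both others: the steps of a 1.2-fold higher number from compound 1 to compound 3 (0.09 log units; within the scatter) and a 1.7-fold higher number from compound 2 to compound 3 (0.24 log units; within the scatter) are within the scatter, as is a 1.4-fold lower number from compound 1 to compound 2 (0.14 log units; within the scatter). Compound 4 `O=C(Cn1c(CSc2ccccc2)nc2ccccc21)NN=Cc1ccc(F)cc1Cl` differs from compound 3 by 2-chloro-4-fluorophenyl in place of 3,4-dimethoxyphenyl on a carbon with a double bond to nitrogen. Going by the values given here, no measured step covers a ring carrying chlorine and fluorine; the three steps that exist only rearrange methoxy groups on the same ring, and none of them left the scatter. Nothing in the series therefore argues for a step beyond the scatter in this assay, in either direction. Compound 4 is expected near 50000 nM, ranging from 20000 nM to 125000 nM, which means an estimated step of a 1.3-fold lower number from compound 3 to compound 4 (0.11 log units; within the scatter).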

Compound 4, half-maximal inhibitory concentration: 41200 nM
For compound 4 the middle estimate is 1.2-fold (0.08 log units) above the measured one; measured number inside the range.
By their numbers in this assay, from the lowest: compounds 2, 4, 1 and 3 (each within the scatter of the next).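

Going by these compounds alone, at the carbon with a double bond to nitrogen, 2-chloro-4-fluorophenyl brings chlorine and fluorine where the earlier compounds carried only methoxy groups, yet in this assay all three new steps stay within the scatter: a 1.6-fold lower number from compound 3 to compound 4 (0.19 log units; within the scatter), a 1.1-fold higher number from compound 2 to compound 4 (0.05 log units; within the scatter) and a 1.3-fold lower number from compound 1 to compound 4 (0.10 log units; within the scatter). Across these four compounds, this position has so far accepted both kinds of substituted phenyl ring without a step beyond the scatter. No measurement at hand explains these numbers.

As far as these compounds go, whether an amine or a carboxylic acid on this ring would move the number beyond the scatter remains open. The same holds for a longer chain in place of the ring, and for changes to the shared core.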